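The compounds below may be only part of what the source reports. "The series", "measured", "known", "first", "only" and "open" are said of these compounds alone.

Of the compounds shown here, three built on one shared core have been tested in a functional assay on HEK293 cells for agonist activity at Vasopressin V2 receptor (Homo sapiens), read by a luciferase reporter and cAMP accumulation; on this read-out lower numbers stand for an effect already at smaller amounts and higher numbers for an effect only at larger amounts of compound. Compound 1 `O=C(NCc1ccc(C(=O)N2CCCCc3ccccc32)c(Cl)c1)Nc1c(F)cccc1F` gives 40 nM. Compound 2 `Cc1cc(C(=O)N2CCCCc3ccccc32)ccc1CNC(=O)NCC(=O)O` gives 180 nM, and compound 3 `Cc1cc(C(=O)N2CCCCc3ccccc32)ccc1CNC(=O)NCC(=O)N(C)C` gives 58 nM. Within the data shown here, the only step between two compounds that differ in a single place is a 3.1-fold lower number from compound 2 to compound 3 (0.49 log units; beyond the scatter). Among the three numbers, compound 3 holds the second highest: its nearest neighbour is compound 1, whose number lies within the scatter of that of compound 3, and its furthest is compound 2, whose number is higher by more than the scatter.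

Compound 4 `Cc1cc(C(=O)N2CCCCc3ccccc32)ccc1CNC(=O)N1CCC[C@H]1C(=S)N(C)C` has not yet been measured. It differs from compound 3 in one place: a group of 10 heavy atoms (7 carbon, 2 nitrogen, 1 sulfur; one five-membered non-aromatic ring with 1 hetero atom) in place of a group of 7 heavy atoms (4 carbon, 2 nitrogen, 1 oxygen; no ring), on a carbonyl carbon. This change sits on the same carbonyl carbon as the change from compound 2 to compound 3, so that modest step is the only one that bears on it. Among the measured compounds shown here, that step, however, exchanged a hydroxy for a dimethylamino; no measured step shows what closing the chain into a five-membered non-aromatic ring, or having a sulfur where an oxygen stood, does here. The step of a 1.5-fold lower number from compound 3 to compound 4 (0.16 log units; within the scatter) is therefore expected to stay near the scatter, leaning slightly toward a lower number. For compound 4 the estimate in this assay is 40 nM, with a range from 12 nM to 130 nM.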

Compound 4, half-maximal effective concentration: 3.2 nM
Compound 4: the middle estimate sits 13-fold (1.10 log units) above what was measured; measured number outside the range, below it.
By their numbers in this assay, from the lowest: compound 4; then compounds 1 and 3 (each within the scatter of the next); then compound 2.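

In this assay, among these compounds, the only earlier step at this carbonyl carbon, a 3.1-fold lower number from compound 2 to compound 3 (0.49 log units; beyond the scatter), was modest, whereas the new group gives an 18-fold lower number from compound 3 to compound 4 (1.26 log units; beyond the scatter). This shows that the position can shift the number much further than the change from hydroxy to dimethylamino suggested, and the full distance from the carboxylic acid is a 56-fold lower number from compound 2 to compound 4 (1.75 log units; beyond the scatter). However, the new group differs in several ways at once, with a five-membered non-aromatic ring, sulfur where oxygen stood and a defined stereocentre, and no supporting measurement explains the large drop.

The compounds shown leave open which of these features carries the effect, since the matching compound with a carbonyl oxygen in place of the sulfur would separate the sulfur from the ring, and an open-chain thioamide would separate the ring from the sulfur. Also open, as far as these compounds go, are the mirror-image form of the stereocentre and whether a six-membered piperidine ring, or a pyrrolidine amide in place of the dimethylamino group, would hold the number as low as compound 4 does.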